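The source may hold more compounds than are shown below. What is called first, only, known or untested is meant among the compounds shown, and "the series" means these compounds.

In a physicochemical assay for lipophilicity, using the shake flask method, measured as octanol-water partition, at pH 7.4 (on this read-out lower numbers stand for lower lipophilicity and higher numbers for higher lipophilicity), compound 1 (`CC(=O)N[C@@H]1CCC[C@H](C(=O)Nc2cc(-c3cnn4c3COCC4)c(Cl)cn2)C1`) gives 2.4 and compound 2 (`CC(=O)N[C@@H]1CCC[C@H](C(=O)Nc2cc(-c3cnn4c3NCCC4)c(Cl)cn2)C1`) gives 2.4 on the same scale, which leaves compound 2 level with compound 1. Compound 3 (`CC(=O)N[C@@H]1CCC[C@H](C(=O)Nc2cc(-c3cnn4c3OCCC4)c(Cl)cn2)C1`) departs from compound 2 in one place, on an aromatic carbon opposite the ring nitrogen (a group of 9 heavy atoms (6 carbon, 2 nitrogen, 1 oxygen; one five-membered aromatic ring with 2 hetero atoms, one six-membered non-aromatic ring with 2 hetero atoms) in place of a group of 9 heavy atoms (6 carbon, 3 nitrogen; one five-membered aromatic ring with 2 hetero atoms, one six-membered non-aromatic ring with 2 hetero atoms), on an aromatic carbon). For the measured compounds named here, the one measured step bearing on this swap is no change at the digits printed from compound 1 to compound 2 (within the scatter) in the same read-out, which also exchanged groups of 9 heavy atoms on that carbon. Accordingly, no step beyond the scatter is expected (a number 0.10 log units higher from compound 2 to compound 3 (within the scatter) as the estimate). For compound 3 the expected value is 2.5 (estimated range 2.2 to 2.8).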

Compound 3, distribution coefficient: 2.6
Estimate against measurement, compound 3: 0.10 log units below, and the stated range covers the measured number.
By their numbers in this assay, from the lowest: compounds 1, 2 and 3 (each within the scatter of the next).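

At this place, opposite the ring nitrogen, a group with 0 hydrogen-bond donors enters for one with 1 hydrogen-bond donor, and this assay records the step (a number 0.20 log units higher from compound 2 to compound 3 (within the scatter)). Two groups with the same atom counts, differing in where the oxygen stands, give a similar result (a number 0.20 log units higher from compound 1 to compound 3 (within the scatter)), so neither swap moves the read-out beyond the scatter. Nothing available accounts for these steps. The compounds shown leave open whether an amine or a carboxylic acid on the six-membered non-aromatic ring would also stay within the scatter.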